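The compounds below may be only part of what the source reports. "The series", "measured", "known", "first", "only" and "open" are said of these compounds alone.

In a functional assay on MCF7 cells (Homo sapiens) for antiproliferative activity, read by MTT assay, with a stated time of 48 h (on this read-out lower numbers stand for stronger inhibition and higher numbers for weaker inhibition), compound 2 `Fc1ccc2[nH]c(-c3cn(-c4ccccc4)nc3-c3ccc(Cl)cc3)nc2c1` gives 2830 nM and compound 1 `FC(F)(F)c1ccc2[nH]c(-c3cn(-c4ccccc4)nc3-c3ccccc3)nc2c1` gives 2660 nM. These two numbers lie within the usual scatter of each other, so they cannot be told apart. Compound 3 `FC(F)(F)c1ccc2[nH]c(-c3cn(-c4ccccc4)nc3-c3ccc(Cl)cc3)nc2c1` keeps all of compound 2 except for one group: trifluoromethyl in place of fluoro on an aromatic carbon. Among the measured compounds shown here, no pair of measured compounds differs by just one change, so this swap has not been tested on its own. Compound 1 also carries trifluoromethyl and gives 2660 nM, which offers only indirect guidance. On that basis, no step beyond the scatter is expected in this assay, and no clear direction can be called. The expected change is a 1.0-fold lower number from compound 2 to compound 3 (0.02 log units; within the scatter). For compound 3 the estimated value is 2700 nM, with an expected range from 1200 nM to 6000 nM.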

Compound 3, half-maximal inhibitory concentration: 4210 nM
Beside the measured number, compound 3's estimate is 1.6-fold (0.19 log units) below it, within the range that was stated.
By their numbers in this assay, from the lowest: compounds 1, 2 and 3 (each within the scatter of the next).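

In this assay the swap of fluoro for trifluoromethyl on this aromatic carbon can now be read on its own: it gives a 1.5-fold higher number from compound 2 to compound 3 (0.17 log units; within the scatter), so these two groups cannot be told apart here. A second single change can also be read, chloro in place of hydrogen on an aromatic carbon, and it gives a 1.6-fold higher number from compound 1 to compound 3 (0.20 log units; within the scatter), which again cannot be told apart from repeat-to-repeat variation. Across these pairs, neither change shifts the number clearly, and no other measurement bears on these results.

From the compounds shown here alone, it remains open whether a different kind of group at this aromatic carbon, such as an amine or a carboxylic acid, would produce a clear step. Also open, going by these compounds, is whether either change would behave the same way on a different core.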